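Imidazole substituent swap on a diphenyl amide scaffold

This account rests on a few compounds, and the source may have more. Where it says the series, first, only, none or still open, it means among the compounds named here.

Measured compounds:
compound 1 `CCN(CC)CCC(c1ccccc1)c1ccccc1` with 197 nM
compound 2 `c1ccc(C(CCn2ccnc2)c2ccccc2)cc1` with 89.1 nM
compound 3 `CCCc1nccn1CCC(C(N)=O)(c1ccccc1)c1ccccc1` with 177 nM

All three were tested in an assay on ileum with muscarinic acetylcholine receptor M3 (Cavia porcellus) as the target; a lower number here means a stronger inhibitor, a higher number a weaker inhibitor. Compound 3 stands second highest of the three numbers; its nearest neighbour is compound 1, and the gap between them lies within the scatter, as does the gap to compound 2. Going by the values given here, the one single-point step among the measured compounds is a 2.2-fold lower number from compound 1 to compound 2 (0.34 log units; beyond the scatter), a modest change from replacing diethylamino with 1H-imidazol-1-yl on the chain.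

Compound 4 `Cc1cncn1CCC(C(N)=O)(c1ccccc1)c1ccccc1` has not yet been measured. It differs from compound 3 by 5-methyl-1H-imidazol-1-yl in place of 2-propyl-1H-imidazol-1-yl on a saturated chain carbon, three bonds along the chain from two aromatic carbons and a carbonyl carbon. Among the compounds with values here, no measured step concerns a change of the substituent on the imidazole ring, so there is nothing among the measured compounds that speaks for a sizeable shift in either direction in this assay. Compound 4 is therefore expected to sit close to compound 3, with the step of a 1.0-fold lower number from compound 3 to compound 4 (0.02 log units; within the scatter) estimated to stay within the scatter. Compound 4 is estimated at 170 nM, with a range from 55 nM to 520 nM.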

Compound 4, antagonist equilibrium constant: 0.86 nM
The estimate for compound 4 lay 200-fold (2.30 log units) above the measured number, outside the stated range (below it).
By their numbers in this assay, from the lowest: compound 4; then compounds 2, 3 and 1 (each within the scatter of the next, the first and the last beyond it).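

In this assay, going by these compounds alone, the substituent on the imidazole ring proves far more decisive than the earlier compounds suggested: the step of a 210-fold lower number from compound 3 to compound 4 (2.31 log units; beyond the scatter) dwarfs the modest 2.2-fold lower number from compound 1 to compound 2 (0.34 log units; beyond the scatter) seen when the whole amine was exchanged. This place on the saturated chain, three bonds along from two aromatic carbons and a carbonyl carbon, is therefore highly sensitive to which alkylated imidazole it carries, although the ring type itself stays the same and only the alkyl group and its place on the ring differ. Nothing available explains why so small an exchange has so large an effect.

Because the group's size and its place on the ring change together, the compounds shown cannot say which of the two accounts for the step. A bare 1H-imidazol-1-yl on the core of compound 3, or an ethyl group in place of the methyl in 5-methyl-1H-imidazol-1-yl, would help to separate them.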